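From a Non-Aromatic Ring to a Furan Group

A few compounds are considered here, and "the series" means these few. Any claim that something is new, unique, unknown or untested is made for them only; others in the source may bear on it.

Among the compounds with values here, two related compounds have numbers so far. In a functional assay on A549 cells (Homo sapiens) for antiproliferative activity, read by XTT assay, with a stated time of 72 h (on this read-out lower numbers stand for stronger inhibition and higher numbers for weaker inhibition), compound 1 (`C=C(C)CCC[C@]1(C)C2=CCC[C@](C)(C[C@@H](O)c3ccoc3)[C@H]2CC[C@H]1C`) gives 66000 nM while compound 2 (`C=C(C)CC[C@]1(C)C2=CCC[C@](C)(C[C@H](O)C3=CC(=O)OC3O)[C@H]2CC[C@H]1C`) gives 4500 nM as the lower of the two numbers. That gap lies beyond the scatter of repeated measurements, so compound 2 is the stronger inhibitor of this pair.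

The next compound is compound 3 (`C=C(C)CC[C@]1(C)C2=CCC[C@](C)(C[C@@H](O)c3ccoc3)[C@H]2CC[C@H]1C`). It differs from compound 2 by one change: a group of 7 heavy atoms (5 carbon, 2 oxygen; one five-membered aromatic ring with 1 hetero atom) in place of a group of 9 heavy atoms (5 carbon, 4 oxygen; one five-membered non-aromatic ring with 1 hetero atom), on a saturated chain carbon bound to a saturated ring carbon and the incoming group is named (furan-3-yl)(hydroxy)methyl. Within the data shown here, no measured pair shows this change alone, so any expectation is indirect. Compound 1 also carries the (furan-3-yl)(hydroxy)methyl group and gives 66000 nM as the higher number, although its structure is not identical to that of compound 3.

In this assay the expected result is weaker inhibition and a higher number, with an estimated 10-fold higher number from compound 2 to compound 3 (1.00 log units; beyond the scatter) that would lie beyond the scatter. For compound 3 the estimated value is 45000 nM with an expected range from 15000 nM to 100000 nM on this read-out.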

Compound 3, half-maximal inhibitory concentration: 34000 nM
Estimate against measurement, compound 3: 1.3-fold (0.12 log units) above; low and high end bracket the measured number.
By their numbers in this assay, from the lowest: compound 2; then compounds 3 and 1 (each within the scatter of the next).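

In this assay, the change on the saturated chain carbon bound to a saturated ring carbon can now be read on its own, with the rest of the molecule unchanged. The step shows a 7.6-fold higher number from compound 2 to compound 3 (0.88 log units; beyond the scatter), so at this place the (furan-3-yl)(hydroxy)methyl group goes with clearly weaker inhibition than the non-aromatic five-membered ring group it replaces. The gap between compound 1 and compound 2 mixed two changes, but the other step, a 1.9-fold lower number from compound 1 to compound 3 (0.29 log units; within the scatter), separates them: swapping 2-methylprop-2-en-1-yl for 1-methylethenyl makes no readable difference when the furan group is present, and nothing measured here explains either step.

As far as these compounds go, it remains open which part of the non-aromatic ring group goes with the stronger inhibition in compound 2, its ring hydroxy group or its carbonyl, and whether a simple amine or a carboxylic acid at the same place would give a similar number. From the compounds shown here alone, it is also open whether the two chains would remain indistinguishable alongside the non-aromatic ring group, since they are compared here only with the furan group in place.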